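The compounds below may be only part of what the source reports. "The series", "measured", "known", "first", "only" and "open" are said of these compounds alone.

Of the compounds shown here, three on a shared core have been measured so far in a functional assay on HCT-116 cells (Homo sapiens) for antiproliferative activity (a lower number here means a stronger inhibitor, a higher number a weaker inhibitor), to date. Compound 1 (`Cc1c2c(n3c1CCN(C(=O)[C@H](C)N)CC[C@H](C)Nc1cc-3ccc1C(N)=O)CC(C)(C)CC2=O`) gives 314 nM here, compound 2 (`Cc1c2c(n3c1CCCN(C)[C@@H](C)[C@H](C)Nc1cc-3ccc1C(N)=O)CC(C)(C)CC2=O`) gives 51 nM here, and compound 3 (`Cc1c2c(n3c1CCN(C)C[C@@H](C)[C@H](C)Nc1cc-3ccc1C(N)=O)CC(C)(C)CC2=O`) gives 27 nM here. Compound 3 and compound 2 lie within the scatter of each other, and compound 1 has a higher number than compound 3, beyond the scatter.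

Compound 4 (`Cc1c2c(n3c1CCN(C(=O)C1(N)CCCC1)C[C@@H](C)[C@H](C)Nc1cc-3ccc1C(N)=O)CC(C)(C)CC2=O`) changes compound 3 in one place. The change is a group of 8 heavy atoms (6 carbon, 1 nitrogen, 1 oxygen; one five-membered non-aromatic ring of carbon only) in place of one carbon atom, on an amine nitrogen in a ring and it replaces the methyl on the amine nitrogen in a ring with a group carrying one five-membered non-aromatic ring of carbon only. For the measured compounds named here, no measured pair isolates this change. Going by the values given here, the only close precedent is compound 1, at 314 nM in this assay with a carbonyl on that ring nitrogen, though it also differs from compound 3 elsewhere. A step of a 5.6-fold higher number from compound 3 to compound 4 (0.74 log units; beyond the scatter) is therefore expected, toward a higher number and beyond the scatter. For compound 4 the estimated value is 150 nM with an expected range from 45 nM to 500 nM in this measurement.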

Compound 4, half-maximal inhibitory concentration: 27 nM
The estimate for compound 4 lay 5.6-fold (0.74 log units) above the measured number, and the stated range ends above it.
By their numbers in this assay, from the lowest: compounds 3, 4 and 2 (each within the scatter of the next); then compound 1.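

In this assay the replacement of the methyl on the amine nitrogen in a ring by the group of 8 heavy atoms gives no change at the digits printed from compound 3 to compound 4 (within the scatter). For the compounds shown here, this is the first pair that isolates a change at this position, and it shows that the position accepts a group carrying one five-membered non-aromatic ring of carbon only, a carbonyl and an amine with no change beyond the scatter. Nothing available accounts for this result.

The compounds shown leave open which part of the entering group matters, since the ring, the carbonyl and the amine all arrive in a single step. A plain acetyl, a cyclopentanecarbonyl lacking the amine, or an open-chain aminoacyl group on the same nitrogen would separate these parts.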